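Two alkyl chains on an aminoglycoside core: expected cytotoxicity

A few compounds are considered here, and "the series" means these few. Any claim that something is new, unique, unknown or untested is made for them only; others in the source may bear on it.

Measured compounds:
- compound 1, `CCCCCCCCCCCO[C@@H]1[C@@H](O)[C@H](O[C@H]2O[C@H](CN)[C@@H](O)[C@H](O)[C@H]2N)[C@@H](N)C[C@H]1N`: 83.4%
- compound 2, `CCCCCCCCCO[C@@H]1[C@@H](N)[C@@H](O[C@H]2[C@H](O)[C@@H](OCCCCCCCCC)[C@H](N)C[C@@H]2N)O[C@H](CN)[C@H]1O`: 67.4%
- compound 3, `CCCCCCCO[C@@H]1[C@@H](O)[C@H](O[C@H]2O[C@H](CN)[C@@H](O)[C@H](O)[C@H]2N)[C@@H](N)C[C@H]1N`: 71.3%

In an ADME assay on J774 cells (Mus musculus) for cytotoxicity, read by MTT assay, with a stated time of 24 h, tested at 30 uM (on this read-out lower numbers stand for a stronger effect and higher numbers for a weaker effect at the one concentration tested), compound 1 gives the highest of the three numbers, meaning the weakest effect of the set. Compound 3 sits nearest, and the step of a number 12.1 percentage points lower from compound 1 to compound 3 (beyond the scatter) is a modest change brought about by hydrogen in place of butyl on a saturated chain carbon, seven bonds along the chain from an oxygen on a saturated carbon. Furthest from compound 1 lies compound 2, which carries two nonyl chains, with a value of 67.4%.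

The unmeasured compound 4, `CCCCCCCCCCCO[C@@H]1[C@@H](N)[C@@H](O[C@H]2[C@H](O)[C@@H](OCCCCCCCCCCC)[C@H](N)C[C@@H]2N)O[C@H](CN)[C@H]1O`, differs from compound 1 by undecyl in place of hydrogen on an oxygen on a saturated carbon, so that a second undecyl chain is present where compound 1 has a hydroxy group. Going by the values given here, no measured step matches this change directly. What the data do show is that compound 1, with a single chain, has the highest value, while compound 2, with two chains, has the lowest. On that basis a drop in this assay is expected for compound 4, of a size comparable to the distance between compound 1 and compound 2, which is the step of a number 21.4 percentage points lower from compound 1 to compound 4 (beyond the scatter). Compound 4 is therefore estimated at 62%, with a range from 45% to 78%.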

Compound 4, a percentage reported as activity, at one concentration (the size of the read-out at that concentration, not a potency): 14.1%
Beside the measured number, compound 4's estimate is 47.9 percentage points above it, and the stated range ends above it.
By their numbers in this assay, from the lowest: compound 4; then compounds 2 and 3 (each within the scatter of the next); then compound 1.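

Swapping hydroxy for undecyloxy on this oxygen gives a step in this assay of a number 69.3 percentage points lower from compound 1 to compound 4 (beyond the scatter), so this position is far from indifferent to what it carries, and the added undecyl chain goes with a much stronger effect on the cells. Going by these compounds alone, the only earlier single-place step, a number 12.1 percentage points lower from compound 1 to compound 3 (beyond the scatter), came from shortening the existing chain and was much smaller, so this oxygen shows a sensitivity to change that the earlier compounds did not reveal. The two steps also lower the number in opposite structural directions, one by removing chain carbons and one by adding a chain, so across these compounds the total amount of chain does not by itself set the read-out, and nothing measured here accounts for the size of the new step.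

As far as these compounds go, what stays open is how the number responds to other groups on this oxygen, such as a butyl chain, a longer tridecyl chain or a chain ending in an amine. With one step at this position, the effect of simply having a chain there cannot be separated from the effect of its length.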